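From a Long Ester Chain to a Short Carboxy Group

This account rests on a few compounds, and the source may have more. Where it says the series, first, only, none or still open, it means among the compounds named here.

Compound 1, `CCOC(=O)CCCCCOc1ccc2c(=O)c(-c3ccc(O)cc3)coc2c1`, gives 5300 nM in an assay (Cricetulus griseus) for inhibition of Monoamine oxidase (Homo sapiens); a lower number here means a stronger inhibitor, a higher number a weaker inhibitor.
Compound 2, `NCCCCOc1ccc2c(=O)c(-c3ccc(O)cc3)coc2c1`, reaches in this assay only the limit > 9000 nM, which is a limit of the assay and not a number.

For the measured compounds named here, compound 1 holds the only numerical value shown in this assay; the other value is a limit, (the limit of > 9000 nM in this assay, at which 1 of the 2 values shown sits). The compound now in question is compound 3, `O=C(O)COc1ccc2c(=O)c(-c3ccc(O)cc3)coc2c1`; the change from compound 1 is carboxy in place of 4-(ethoxycarbonyl)butyl on a saturated chain carbon bound to an oxygen on an aromatic ring. Going by the values given here, the one measured step, an at least 1.6-fold higher number from compound 1 to compound 2 (0.22 log units; that floor lies within the scatter), bears on this: there too an ester-ended chain gave way to a smaller group with a hydrogen-bond donor, and the number rose at least to the limit. Compound 3 carries the same kind of change, with a still smaller group and a hydrogen-bond donor entering. Compound 3 is therefore expected to move in the same direction, toward a weaker inhibitor, by a step beyond the scatter, a 2.5-fold higher number from compound 1 to compound 3 (0.39 log units; beyond the scatter), quite possibly only as a limit. The estimate for compound 3 is 13000 nM, within 4000 nM to 45000 nM.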

Compound 3, half-maximal inhibitory concentration: >> 9000 nM
Compound 3 gave a limit, no number (the forecaster's own chance of this, stated with the estimate: 60%); the middle value lies beyond the limit too.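

In this assay, compound 3 gives a limit of the assay and not a number: the limit of >> 9000 nM in this assay, at which 1 of the 3 values shown sits. Carboxy in place of 4-(ethoxycarbonyl)butyl on a saturated chain carbon bound to an oxygen on an aromatic ring gives an at least 1.6-fold higher number from compound 1 to compound 3 (0.22 log units; that floor lies within the scatter), so this change is not shown to reach beyond the scatter. What compound 3 adds is a second replacement of the long ester chain, this time ending in carboxy and not in the amino group of compound 2, that also yields no number, which leaves compound 1 the only one of the three with a numerical value, while the step between compound 2 and compound 3 cannot be read.

The compounds shown leave open whether the number of compound 1 goes with the ethyl ester or with the length of its chain, a question that a carboxylic acid at the end of the longer chain, or an ethyl ester on the short chain of compound 3, could separate. They also leave open how far beyond their limits compound 2 and compound 3 lie.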